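The source may hold more compounds than are shown below. What is called first, only, known or untested is meant among the compounds shown, and "the series" means these compounds.

Compound 3 `C[C@H]1[C@H](NC(=O)OCCCCC2CCCCC2)C(=O)N1Oc1ccc(S(C)(=O)=O)cc1` gives 6 nM in an assay on HEK293 cells for inhibition of N-acylethanolamine-hydrolyzing acid amidase (Homo sapiens), read by fluorescence, with stated times of 10 min and 50 min (a higher number here means a weaker inhibitor, a lower number a stronger inhibitor), the lowest of the three numbers measured. Compound 1 `CCCON1C(=O)[C@@H](NC(=O)OCCCCC2CCCCC2)[C@@H]1C` gives 133 nM, and compound 2 `C[C@H]1[C@H](NC(=O)OCCCCC2CCCCC2)C(=O)N1OCCCCC1CCCCC1` gives 3470 nM. The step of a 22-fold lower number from compound 1 to compound 3 (1.35 log units; beyond the scatter) and the step of a 580-fold lower number from compound 2 to compound 3 (2.76 log units; beyond the scatter) both show that replacing a chain on the oxygen by the 4-(methylsulfonyl)phenyl group brings a large fall. Compound 4 `C[C@H]1[C@H](NC(=O)OCCCCC2CCCCC2)C(=O)N1Oc1ccccc1S(C)(=O)=O` differs from compound 3 only in how the same atoms are joined: 2-(methylsulfonyl)phenyl in place of 4-(methylsulfonyl)phenyl on an oxygen. Within the data shown here, no measured step shows what moving the methylsulfonyl within the aryl group does, so the size and direction of the expected change are uncertain; a modest rise is expected, a 6.7-fold higher number from compound 3 to compound 4 (0.82 log units; beyond the scatter). Compound 4 is therefore estimated at 40 nM, within a range from 8 nM to 250 nM.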

Compound 4, half-maximal inhibitory concentration: 6 nM
The estimate for compound 4 lay 6.7-fold (0.82 log units) above the measured number; measured number outside the range, below it.
By their numbers in this assay, from the lowest: compounds 3 and 4 (each within the scatter of the next); then compound 1; then compound 2.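

In this assay, moving the methylsulfonyl within the aryl group gives no change at the digits printed from compound 3 to compound 4 (within the scatter), so on this oxygen the 2-(methylsulfonyl)phenyl and 4-(methylsulfonyl)phenyl groups cannot be told apart. The large falls seen on replacing the chains carry over to the new group, with a 22-fold lower number from compound 1 to compound 4 (1.35 log units; beyond the scatter) and a 580-fold lower number from compound 2 to compound 4 (2.76 log units; beyond the scatter). No evidence is available on why the two aryl groups read alike. The compounds shown leave open whether the methylsulfonyl is needed at all, as an unsubstituted phenyl on this oxygen would show. They also leave open how a carboxylic acid in its place would read.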